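This account rests on a few compounds, and the source may have more. Where it says the series, first, only, none or still open, it means among the compounds named here.

Measured compounds:
Compound 1, `COC(=O)C[C@H](NC(=O)OC(C)(C)C)C(=O)N(Cc1ccc(F)cc1)C1(C(=O)NCc2ccccc2)CCN(Cc2ccccc2)CC1`, in an ADME assay on MDCK cells (Canis lupus familiaris) for cytotoxicity, read by microscopy, with a stated time of 72 h (on this read-out higher numbers stand for lower toxicity in this test and lower numbers for higher toxicity in this test), gives a limit of > 100000 nM.
Compound 2, `COC(=O)C[C@H](NC(=O)OC(C)(C)C)C(=O)N(Cc1ccc(F)cc1)C1(C(=O)NC2CCCCC2)CCN(Cc2ccccc2)CC1`, gives 100000 nM.
Compound 3, `COC(=O)C[C@H](NC(=O)OCc1ccccc1)C(=O)N(Cc1ccc(F)cc1)C1(C(=O)NCc2ccccc2)CCN(Cc2ccccc2)CC1`, gives 2600 nM.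

Among the measured compounds shown here, compound 1 sits at the limit of this assay: its value is a limit, not a number, and it is the one value at the limit of > 100000 nM in this assay, at which 1 of the 3 values shown sits. Compound 4, `COC(=O)C[C@H](NC(=O)OC(C)(C)C)C(=O)N(Cc1ccc(F)cc1)C1(C(=O)NCc2ccccc2)CCN(Cc2cccc(F)c2)CC1`, differs from compound 1 in one place: fluoro in place of hydrogen on an aromatic carbon. Two measured steps start from compound 1. One is a number no higher from compound 1 to compound 2 (the limit leaves the size open), a step whose size the limit leaves open. The other is an at least 38-fold lower number from compound 1 to compound 3 (1.58 log units; beyond the scatter), a large step. For the measured compounds named here, neither of these steps changes a benzyl to a 3-fluorobenzyl, so neither bears directly on the change to compound 4, and no measured step shows what a fluoro in place of hydrogen does here. For compound 4 a step within the scatter is therefore expected, a number no higher from compound 1 to compound 4 (the limit leaves the size open), with the value most likely again a limit. Compound 4 is estimated at 100000 nM, with a range from 30000 nM to 300000 nM.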

Compound 4, minimum cytotoxic concentration: 84000 nM
Beside the measured number, compound 4's estimate is 1.2-fold (0.08 log units) above it, within the range that was stated.
By their numbers in this assay, from the lowest: compound 3; then compounds 4 and 2 (each within the scatter of the next).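

In this assay, fluoro on this aromatic carbon of the benzyl group still leaves a high number, which here stands for low toxicity in this test, and the change is read as an at least 1.1-fold lower number from compound 1 to compound 4 (0.07 log units; that floor lies within the scatter). On these data alone, compound 1 gives > 100000 nM, which is a limit and not a number, so this step has only a floor and its true size stays open: the limit of > 100000 nM in this assay, at which 1 of the 4 values shown sits. The change may therefore be very small or larger, and the data do not separate these two readings.

As far as these compounds go, it remains open whether a chloro, a methoxy, an amine or a carboxylic acid in place of this fluoro would also leave the number high. From the compounds shown here alone, it is also open what the same fluoro would do with the benzyl group on the oxygen of compound 3, which gives 2600 nM.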